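The source may report more compounds than this note shows. Statements on the series, on what has been measured and on what is new or still open speak of the compounds shown alone.

Measured compounds:
- compound 1 `N#Cc1cccc(C#Cc2cccc(C#N)n2)c1` gives 20 nM
- compound 2 `N#Cc1cc(F)cc(C#Cc2cccc(F)n2)c1` gives 80 nM
- compound 3 `CC(=O)c1cccc(C#Cc2cc(F)cc(C#N)c2)n1` gives 240 nM

All three were tested in an in vitro functional assay on HEK293-A cells for agonist activity at metabotropic glutamate receptor 5 (Rattus norvegicus), read by ELISA; on this read-out lower numbers stand for stronger inhibition and higher numbers for weaker inhibition. Among them compound 1 has the lowest number, with compound 2 next and compound 3 furthest away, both gaps beyond the scatter. The unmeasured compound 4 `CCCCc1cccc(C#Cc2cccc(C#N)c2)n1` differs from compound 1 in one place: butyl in place of cyano on an aromatic carbon. Within the data shown here, the only measured step that touches the same position is the one from compound 2 to compound 3, where an acetyl replaced a fluoro on the carbon next to the ring nitrogen and gave a 3.0-fold higher number from compound 2 to compound 3 (0.48 log units; beyond the scatter). That step shows that changing the group at this position shifts the number by a modest amount, though neither fluoro, acetyl nor butyl matches the cyano that leaves compound 1, so the comparison is only indirect. Among the measured compounds shown here, no measured pair shows what a butyl does anywhere on either ring. Given that the one relevant step moved the number upward, a modest rise beyond the scatter is expected in this assay for compound 4, with real uncertainty in both directions. Compound 4 is therefore estimated at 80 nM, within a range of 20 nM to 400 nM, which corresponds to an expected step of a 4.0-fold higher number from compound 1 to compound 4 (0.60 log units; beyond the scatter).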

Compound 4, half-maximal inhibitory concentration: 700 nM
For compound 4 the middle estimate is 8.8-fold (0.94 log units) below the measured one; measured number above the stated range.
By their numbers in this assay, from the lowest: compound 1; then compound 2; then compound 3; then compound 4.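

In this assay, among these compounds, the swap of cyano for butyl next to the ring nitrogen gives a 35-fold higher number from compound 1 to compound 4 (1.54 log units; beyond the scatter) and counts as a large step, whereas the one earlier change at this position, a 3.0-fold higher number from compound 2 to compound 3 (0.48 log units; beyond the scatter), was modest and started from a fluoro rather than a cyano. Among the compounds shown here, the position is therefore far more sensitive to what sits on it than the earlier compounds showed, and with the rest of compound 1 held fixed, this single change greatly weakens inhibition. No independent measurement here explains why this swap has so large an effect.

The compounds shown leave open whether the rise comes mainly from losing the cyano or from bringing in the butyl, since this one change does both, and a plain hydrogen, a methyl or a propyl chain at this position would help to tell those two apart. They also leave open whether a butyl would have a similar effect on the core of compound 2, which carries fluoro on its other ring.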